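The source may report more compounds than this note shows. Statements on the series, on what has been measured and on what is new or still open speak of the compounds shown alone.

In a functional assay (aorta) with Oryctolagus cuniculus as the target (on this read-out lower numbers stand for stronger inhibition and higher numbers for weaker inhibition), three compounds have been measured so far. Compound 1 `OCc1ccc(-c2nn(Cc3c(F)cccc3F)c3ccccc23)o1` gives 15000 nM, compound 2 `NS(=O)(=O)c1ccc(-c2nn(Cc3ccccc3F)c3ncccc23)o1` gives 8000 nM, and compound 3 `Fc1ccccc1Cn1nc(C2=NCCN2)c2cccnc21` gives 3200 nM. Compound 3 stands lowest of the three, and its gaps to compound 2 and to compound 1 both lie beyond the usual scatter, so it is the most potent of the measured set. Compound 4 `Fc1ccccc1Cn1nc(-c2cc[nH]n2)c2cccnc21` has not yet been measured in this assay; it differs from compound 3 by a group of 5 heavy atoms (3 carbon, 2 nitrogen; one five-membered aromatic ring with 2 hetero atoms) in place of a group of 5 heavy atoms (3 carbon, 2 nitrogen; one five-membered non-aromatic ring with 2 hetero atoms), on an aromatic carbon. Within the data shown here, no measured pair shows this change, so its effect is unknown. The step is expected to raise the number, probably beyond the scatter, by an uncertain amount, and a 1.9-fold higher number from compound 3 to compound 4 (0.27 log units; within the scatter) is the estimated step. For compound 4 the estimate is 6000 nM, within a range from 1500 nM to 25000 nM.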

Compound 4, half-maximal inhibitory concentration: 1800 nM
Compound 4: middle estimate off by 3.3-fold (0.52 log units), on the high side; the measured number falls inside the stated range.
By their numbers in this assay, from the lowest: compounds 4 and 3 (each within the scatter of the next); then compounds 2 and 1 (each within the scatter of the next).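

In this assay, among these compounds, placing 1H-pyrazol-3-yl on this aromatic carbon in place of the non-aromatic five-membered ring gives a 1.8-fold lower number from compound 3 to compound 4 (0.25 log units; within the scatter), the first single-change comparison at this position. The aromatic and non-aromatic rings therefore cannot be told apart here, so this change leaves the read-out within the scatter. Nothing available explains this outcome. Still open, as far as these compounds go, is how a non-ring group, such as an amine or a carboxylic acid, would read on this aromatic carbon. From the compounds shown here alone, whether the same change behaves alike on a different core also remains unknown.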